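The source may hold more compounds than are shown below. What is called first, only, known or untested is meant among the compounds shown, and "the series" means these compounds.

In a functional assay on MCF7 cells (Homo sapiens) for antiproliferative activity, read by MTT assay, with a stated time of 72 h (a lower number here means a stronger inhibitor, a higher number a weaker inhibitor), compound 2 `O=[N+]([O-])c1ccc(-c2csc(N3N=C(c4ccc(N5CCCCC5)cc4)CC3c3ccc(Cl)cc3)n2)cc1` gives > 100000 nM, which is a limit of the assay and not a number. Compound 1 `Clc1ccc(C2CC(c3ccc(N4CCCCC4)cc3)=NN2c2nc(-c3ccccc3)cs2)cc1` gives 28400 nM, and compound 3 `Fc1ccc(-c2csc(N3N=C(c4ccc(N5CCCCC5)cc4)CC3c3ccc(Cl)cc3)n2)cc1` gives 23100 nM. Compound 4 `Clc1ccc(-c2csc(N3N=C(c4ccc(N5CCCCC5)cc4)CC3c3ccc(Cl)cc3)n2)cc1` has chloro in place of nitro on an aromatic carbon. The closest measured change is fluoro in place of nitro, an at least 4.3-fold lower number from compound 2 to compound 3 (0.63 log units; beyond the scatter). Removing the nitro group's hydrogen counterpart gives the same picture in reverse, with an at least 3.5-fold higher number from compound 1 to compound 2 (0.54 log units; beyond the scatter), while a 1.2-fold lower number from compound 1 to compound 3 (0.09 log units; within the scatter) shows that fluoro and hydrogen do not separate. A step of similar size towards a lower number is therefore expected in this assay. The estimated step is an at least 4.0-fold lower number from compound 2 to compound 4 (0.60 log units; beyond the scatter). For compound 4 the expected value is 25000 nM, within an estimated range of 10000 nM to 60000 nM.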

Compound 4, half-maximal inhibitory concentration: > 100000 nM
Compound 4 gave a limit, no number; the forecaster's own chance of this, stated with the estimate: 8%; at least 4.0-fold (0.60 log units) between middle value and limit.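

On this ring, para to a large group, the tolerance seen with fluoro does not extend to chloro: an at least 4.3-fold higher number from compound 3 to compound 4 (0.63 log units; beyond the scatter), and an at least 3.5-fold higher number from compound 1 to compound 4 (0.54 log units; beyond the scatter). The loss of activity is therefore no longer unique to nitro, since a single chloro atom at this place also separates from hydrogen and fluoro. Compound 2 and compound 4 both stand at a limit of the assay, not at a number, so the step between them cannot be read: the limit of > 100000 nM in this assay, at which 2 of the 4 values shown sit.

The compounds shown leave open how far past that limit either compound lies. They also leave open whether a methyl, a methoxy or an amine at this place would fall with fluoro or with chloro.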